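The source may hold more compounds than are shown below. What is called first, only, known or untested is meant among the compounds shown, and "the series" means these compounds.

Compound 1 `CCCCCCN[C@@H]1C=C[C@H](O)[C@H](O)[C@H]1O` gives 56000 nM in an assay for inhibition of beta-galactosidase (Homo sapiens), read by fluorescence, with a stated time of 30 min, at pH 4.5; on this read-out lower numbers stand for stronger inhibition and higher numbers for weaker inhibition.
Compound 2 `OCCCN[C@@H]1C=C[C@H](O)[C@H](O)[C@H]1O` gives > 1000000 nM, which is a limit of the assay and not a number.

Compound 2 therefore sits at the limit of > 1000000 nM in this assay, at which 1 of the 2 values shown sits. Going by the values given here, the single measured step, an at least 17-fold higher number from compound 1 to compound 2 (1.25 log units; beyond the scatter), replaced a plain alkyl chain by one carrying a hydroxy group and weakened inhibition well beyond the scatter. Compound 3 `CCC(CC)CN[C@@H]1C=C[C@H](O)[C@H](O)[C@H]1O` makes the reverse kind of change: pentan-3-yl in place of 2-hydroxyethyl on a saturated chain carbon bound to an amine nitrogen. Taking the hydroxy group away and putting an alkyl group in its place is expected to pull the number back down toward where compound 1 stands, so the step is estimated as an at least 16-fold lower number from compound 2 to compound 3 (1.22 log units; beyond the scatter). Compound 3 is thus expected to give about 60000 nM, between 15000 nM and 300000 nM.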

Compound 3, half-maximal inhibitory concentration: 15000 nM
Compound 3: middle estimate off by 4.0-fold (0.60 log units), on the high side; measured number inside the range.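

On a saturated chain carbon bound to an amine nitrogen, pentan-3-yl does far better than 2-hydroxyethyl, with an at least 66-fold lower number from compound 2 to compound 3 (1.82 log units; beyond the scatter). Compound 2 stands at a limit of the assay, so this step gives only a bound: the limit of > 1000000 nM in this assay, at which 1 of the 3 values shown sits. Pentan-3-yl also beats the pentyl it replaces, with a 3.7-fold lower number from compound 1 to compound 3 (0.57 log units; beyond the scatter), so the branched group gives stronger inhibition than the straight chain of compound 1.

The compounds shown leave open how a cyclohexyl ring, a longer chain or an amine on the chain would compare here. They also leave open whether a hydroxy group on a branched chain would weaken inhibition as much.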